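The source may hold more compounds than are shown below. What is called first, only, known or untested is meant among the compounds shown, and "the series" means these compounds.

Measured compounds:
- compound 1, `Cc1ccc(S(=O)(=O)N2CC(c3ccc(Br)cc3)NC2=O)cc1`: > 253000 nM
- compound 2, `O=C1NC(c2ccc(Br)cc2)CN1S(=O)(=O)c1ccc(Cl)cc1`: 111000 nM
- compound 3, `Cc1ccc(C2CNC(=O)N2S(=O)(=O)c2ccc(Cl)cc2)cc1`: 255000 nM

Series notes. In a functional assay on SK-MEL-2 cells (Homo sapiens) for cytotoxicity (a higher number here means a weaker inhibitor, a lower number a stronger inhibitor), compound 2 gives 111000 nM. For compound 1 the result in this assay is a limit of the assay, not a number: > 253000 nM, which is the limit of > 253000 nM in this assay, at which 1 of the 3 values shown sits. Compound 3 in this assay gives 255000 nM, a higher number than that of compound 2; the difference between the core of compound 2 and the core of compound 3 is not broken down here.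

Going by the values given here, the one step that can be followed is that from compound 2 to compound 1, (methyl in place of chloro on an aromatic carbon), which gave an at least 2.2-fold higher number from compound 2 to compound 1 (0.35 log units; beyond the scatter). The unmeasured compound 4, `Cc1ccc(C2CNC(=O)N2S(=O)(=O)c2ccc(C)cc2)cc1`, differs from compound 3 by the same change, (methyl in place of chloro on an aromatic carbon), made on the same kind of place.

Expectation for compound 4 in this assay: the same direction as the measured step, since compound 3 starts from 255000 nM, already a high number. Compound 4 is expected to move by a 2.2-fold higher number from compound 3 to compound 4 (0.34 log units; beyond the scatter). For compound 4 there is a high chance that the assay reports only a limit rather than a number. The estimate for compound 4 is 560000 nM, with a range from 250000 nM to 1500000 nM, resting on the step from compound 2 to compound 1.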

Compound 4, half-maximal inhibitory concentration: 234000 nM
The estimate for compound 4 lay 2.4-fold (0.38 log units) above the measured number; measured number outside the range, below it.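

In this assay, methyl in place of chloro on an aromatic carbon, read on the core of compound 3 as 4-chlorophenyl to 4-methylphenyl, gives a 1.1-fold lower number from compound 3 to compound 4 (0.04 log units; within the scatter), so on this core the change cannot be told apart from the scatter. This does not show that the change carries from one core to another with the same size, nor does it show that the two cores respond differently to it: the same change on two cores in this assay, an at least 2.2-fold higher number (0.35 log units; beyond the scatter) from compound 2 to compound 1 and a 1.1-fold lower number (0.04 log units; within the scatter) from compound 3 to compound 4; the limit leaves it open whether they differ. The comparison stays unresolved on the side of the earlier step, where compound 1 gives a limit of the assay and not a number: the limit of > 253000 nM in this assay, at which 1 of the 4 values shown sits.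

The compounds shown carry only chloro, methyl and bromo as aromatic groups, so it remains open whether an amine or a carboxylic acid in the place of the chloro would move the number on either core. Also open, on these data alone, are the actual size of the step to compound 1 and whether the same change would behave alike on further cores, since two cores give too little to establish a pattern in either direction.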